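Fluoro for Nitro on the Benzamide: Expected Toxicity Unchanged

The source may hold more compounds than are shown below. What is called first, only, known or untested is meant among the compounds shown, and "the series" means these compounds.

Compound 3 `COc1ccc(-c2cnc(NC(=O)c3ccc([N+](=O)[O-])cc3)n2C)cc1` was examined in a toxicity assay on THP-1 cells (Homo sapiens) for inhibition; on this read-out lower numbers stand for higher toxicity in this test and higher numbers for lower toxicity in this test. In this assay compound 3 gives only a limit of the assay, > 100000 nM, and no number. The two companions show the same picture. Compound 1 `CCCCn1c(-c2ccc(OC)cc2)cnc1NC(=O)c1ccc(F)cc1` sits at a limit, > 100000 nM, in this assay. Compound 2 `Cc1ccccc1-c1cnc(NC(=O)c2ccc(F)cc2)n1C` likewise reports a limit, > 50000 nM, in this assay. All three values are thus limits, two at the limit of > 100000 nM in this assay, at which 2 of the 3 values shown sit, and one at the limit of > 50000 nM in this assay, at which 1 of the 3 values shown sits. Compound 4 `COc1ccc(-c2cnc(NC(=O)c3ccc(F)cc3)n2C)cc1` has not been measured; it differs from compound 3 by fluoro in place of nitro on an aromatic carbon. Going by the values given here, no step between measured compounds is known here. Compound 1 already carries a fluoro group on its benzamide and shows the limit > 100000 nM in this assay. The step of a number no higher from compound 3 to compound 4 (the limit leaves the size open) is therefore expected to be none beyond the scatter. Compound 4 is estimated at 100000 nM, within 50000 nM to 300000 nM, most likely again only as a limit.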

Compound 4, half-maximal cytotoxic concentration: >= 50000 nM
Compound 4: no number, only a limit (the forecaster's own chance of this, stated with the estimate: 85%); the middle value lies beyond the limit too.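

In this assay, going by these compounds alone, compound 4 gives only a limit, like compound 1, compound 2 and compound 3, so no step to compound 4 can be read. The compounds shown leave open at what concentration any of them turns toxic.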